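Swapping methoxy for dimethylamino on a second core

The source may report more compounds than this note shows. Statements on the series, on what has been measured and on what is new or still open speak of the compounds shown alone.

The study measures growth inhibition of DU-145 cells in a functional assay on DU-145 cells (Homo sapiens) for inhibition, read by trypan blue exclusion, with a stated time of 96 h; a lower number here means a stronger inhibitor of growth, a higher number a weaker inhibitor of growth. Two compounds share one core: compound 2 `COc1ccc(/C=C(/SCc2ccc(Cl)cc2)C(=O)c2ccc(C(=O)O)cc2)cc1` and compound 1 `CN(C)c1ccc(/C=C(/SCc2ccc(Cl)cc2)C(=O)c2ccc(C(=O)O)cc2)cc1`. In this assay compound 2 gives 10000 nM, while compound 1 gives 1000 nM. The change between them is dimethylamino in place of methoxy on an aromatic carbon, and it gave a 10-fold lower number from compound 2 to compound 1 (1.00 log units; beyond the scatter).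

Compound 3 `COc1ccc(/C=C(\C(=O)c2ccc(Br)cc2)S(=O)(=O)c2ccc(C)cc2)cc1` rests on a different core; how that core differs from the core of compound 2 is not broken down here. In this assay compound 3 gives 1000 nM, level with compound 1 at the digits printed, and these two stand together as the lowest of the three numbers, with compound 2 the furthest away.

Compound 4 `Cc1ccc(S(=O)(=O)/C(=C/c2ccc(N(C)C)cc2)C(=O)c2ccc(Br)cc2)cc1` has not been measured. Going by the values given here, it differs from compound 3 by dimethylamino in place of methoxy on an aromatic carbon, which is the same change as the one from compound 2 to compound 1, at the same place on the ring. Because compound 3 starts from 1000 nM and the same change on the other core produced a 10-fold lower number from compound 2 to compound 1 (1.00 log units; beyond the scatter), a step of similar size is expected from compound 3 to compound 4, namely a 6.7-fold lower number from compound 3 to compound 4 (0.82 log units; beyond the scatter). Among the compounds with values here, only one prior instance of this change exists, and on a different core, so the expectation carries a wide band. Compound 4 is therefore estimated at 150 nM, with the range 30 nM to 600 nM in this assay.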

Compound 4, concentration for 50% growth inhibition: 50000 nM
The estimate for compound 4 lay 330-fold (2.52 log units) below the measured number; the measured number lies above the stated range.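

On the core of compound 3, the exchange of 4-methoxyphenyl for 4-(dimethylamino)phenyl gave a 50-fold higher number from compound 3 to compound 4 (1.70 log units; beyond the scatter) in this assay, so the change that had strengthened growth inhibition on the core of compound 2 weakened it here. Within these four compounds, the change therefore did not carry from one core to the other in size or in direction: the same change on two cores in this assay, a 10-fold lower number (1.00 log units; beyond the scatter) from compound 2 to compound 1 and a 50-fold higher number (1.70 log units; beyond the scatter) from compound 3 to compound 4, 500-fold (2.70 log units) apart, beyond the scatter of two such steps

This does not show why the two steps part ways, and with a single pair on each core, it does not show how either step would hold up on further pairs built on the same core.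

The compounds shown leave open which of the features separating the two cores goes with the reversal: the carboxylic acid of compound 1 and compound 2 against the bromine of compound 3 and compound 4, or the chlorobenzyl sulfide against the methylphenyl sulfone. They also leave open how a hydroxy group or a primary amine on the same aromatic carbon would read on each core, and whether an ester in place of the carboxylic acid would bring the two steps closer together.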